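Two ether side chains on a shared amide core

A few compounds are considered here, and "the series" means these few. Any claim that something is new, unique, unknown or untested is made for them only; others in the source may bear on it.

Measured so far:
Compound 1, `COC(C)(C)[C@@H](O)C(=O)N1N=CC[C@H]1C(=O)NCc1cc(Cl)ccc1-n1cnnn1`, 3700 nM
Compound 2, `O=C(NCc1cc(Cl)ccc1-n1cnnn1)[C@@H]1CCON1C(=O)[C@H](O)c1ccccc1`, 1500 nM

The account follows a single change made to compound 1. In a functional assay on a cell-free system (plasma, Homo sapiens), with a stated time of 3 min (on this read-out lower numbers stand for stronger inhibition and higher numbers for weaker inhibition), compound 1 gives 3700 nM, the highest of the two numbers on hand. The nearest neighbour is compound 2, which in this assay gives 1500 nM, a gap that lies beyond the usual scatter. Compound 3, `CC(C)(C)OC[C@@H](O)C(=O)N1N=CC[C@H]1C(=O)NCc1cc(Cl)ccc1-n1cnnn1`, differs from compound 1 in one place: (tert-butoxy)methyl in place of 1-methoxy-1-methylethyl on a saturated chain carbon bound to a carbonyl carbon and an oxygen on a saturated carbon. Among the compounds with values here, no pair of measured compounds shows what such an exchange does, so the size of the step rests on expectation alone. The change keeps the count of hydrogen-bond acceptors and adds one heavy atom, and the step from compound 1 to compound 3 is expected to be small, a 1.2-fold lower number from compound 1 to compound 3 (0.09 log units; within the scatter), with no clear direction beyond the scatter. Compound 3 is therefore estimated at 3000 nM, within a range of 1000 nM to 9000 nM.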

Compound 3, half-maximal inhibitory concentration: 750 nM
Estimate against measurement, compound 3: 4.0-fold (0.60 log units) above; the measured number lies below the stated range.
By their numbers in this assay, from the lowest: compounds 3 and 2 (each within the scatter of the next); then compound 1.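

On the saturated chain carbon bound to a carbonyl carbon and an oxygen on a saturated carbon, the exchange of 1-methoxy-1-methylethyl for (tert-butoxy)methyl gives the first one-place comparison, and in this assay it brings a 4.9-fold lower number from compound 1 to compound 3 (0.69 log units; beyond the scatter). This position therefore responds to the make-up of the side chain: both groups are open chains with no net charge and the same counts of hydrogen-bond donors and acceptors, and the entering group adds one heavy atom. No measurement on hand gives a reason for the step.

The compounds shown leave open whether the step follows the place of the ether oxygen in the chain or the tert-butyl end. They also leave open how an amine, a carboxylic acid or a longer chain would fare at this position.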